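The source may hold more compounds than are shown below. What is called first, only, known or untested is meant among the compounds shown, and "the series" means these compounds.

Compound 2 `Cc1cc(C)c(-c2cccc(N)n2)cc1NC(=O)c1ccc(OCc2ccccn2)cc1`: 2000 nM; compound 1 `Cc1cc(C)c(-c2cccnc2)cc1NC(=O)c1ccc(OCc2ccccn2)cc1`: 9000 nM.

In a physicochemical assay for solubility, at pH 7.4 (a higher number here means a more soluble compound, a lower number a less soluble compound), compound 2 gives the lowest of the two numbers, with compound 1 giving 9000 nM, a step of a 4.5-fold lower number from compound 1 to compound 2 (0.65 log units; beyond the scatter). Compound 3 `Cc1cc(C)c(-c2ccc(N)nn2)cc1NC(=O)c1ccc(OCc2ccccn2)cc1` differs from compound 2 by 6-aminopyridazin-3-yl in place of 6-aminopyridin-2-yl on an aromatic carbon. Among the compounds with values here, no measured step involves this change; the only step known, a 4.5-fold lower number from compound 1 to compound 2 (0.65 log units; beyond the scatter), concerns a different exchange at the same place and does not bear on it. Compound 3 is therefore expected to give about 2500 nM in this assay, between 700 nM and 9000 nM, a step of a 1.3-fold higher number from compound 2 to compound 3 (0.10 log units; within the scatter) that may well stay within the scatter.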

Compound 3, solubility: 6000 nM
Compound 3: middle estimate off by 2.4-fold (0.38 log units), on the low side; measured number inside the range.
By their numbers in this assay, from the lowest: compound 2; then compounds 3 and 1 (each within the scatter of the next).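

In this assay, this position on the shared core responds to the ring itself and not only to the presence of an amine: with an amine kept on the ring, 6-aminopyridazin-3-yl in place of 6-aminopyridin-2-yl gives a 3.0-fold higher number from compound 2 to compound 3 (0.48 log units; beyond the scatter). Against the ring without an amine, the result is a 1.5-fold lower number from compound 1 to compound 3 (0.18 log units; within the scatter), so an amine-bearing ring at this position need not move the number beyond the scatter. Nothing available here explains this difference between the two rings. The compounds shown leave open what a methoxy group or a hydroxyl would give in place of the amine on these rings.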